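Chloro for methoxy on compound 3

This account rests on a few compounds, and the source may have more. Where it says the series, first, only, none or still open, it means among the compounds named here.

In a functional assay on A-375 cells (Homo sapiens) for antiproliferative activity, read by MTT assay, with a stated time of 72 h (on this read-out higher numbers stand for weaker inhibition and lower numbers for stronger inhibition), compound 1 (`COc1ncc(-c2ccc3c(c2)N(c2ccc(F)cc2)C(=O)CO3)cc1NS(=O)(=O)c1ccc(F)cc1`), with a 4-fluorophenyl group, reads > 40000 nM as a limit of the assay, not a number. Among the measured compounds shown here, compound 2 (`COc1ncc(-c2ccc3c(c2)N(C2CC2)C(=O)CO3)cc1NS(=O)(=O)c1ccc(F)cc1`) gives 23900 nM and compound 3 (`COc1ccc(N2C(=O)COc3ccc(-c4cnc(OC)c(NS(=O)(=O)c5ccc(F)cc5)c4)cc32)cc1`) gives 18400 nM within the scatter of each other, so compound 3 stands level with the only other true number. Putting 4-chlorophenyl in place of 4-methoxyphenyl gives compound 4 (`COc1ncc(-c2ccc3c(c2)N(c2ccc(Cl)cc2)C(=O)CO3)cc1NS(=O)(=O)c1ccc(F)cc1`), which is chloro in place of methoxy on an aromatic carbon. The closest measured change, methoxy in place of fluoro, runs the other way and gave an at least 2.1-fold lower number from compound 1 to compound 3 (0.33 log units; beyond the scatter) as its size. Compound 4 also lacks the methoxy, so a modest move towards weaker inhibition is expected in this assay here. The expected change is a 1.6-fold higher number from compound 3 to compound 4 (0.21 log units; within the scatter) by this estimate. Compound 4 is estimated at 30000 nM with an expected range from 15000 nM to 55000 nM overall.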

Compound 4, half-maximal inhibitory concentration: 24100 nM
For compound 4 the middle estimate is 1.2-fold (0.10 log units) above the measured one; measured number inside the range.
By their numbers in this assay, from the lowest: compounds 3, 2 and 4 (each within the scatter of the next). At a limit, above all of these: compound 1.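

Chloro in place of methoxy on this aromatic carbon leaves compound 4 level with compound 3 in this assay (a 1.3-fold higher number from compound 3 to compound 4 (0.12 log units; within the scatter)), and the same holds for 4-chlorophenyl in place of cyclopropyl (a 1.0-fold higher number from compound 2 to compound 4 (0.00 log units; within the scatter)). Chloro in place of fluoro can be read only as a floor (an at least 1.6-fold lower number from compound 1 to compound 4 (0.22 log units; that floor lies within the scatter)), and the value of compound 1 is a limit of the assay, not a number: the limit of > 40000 nM in this assay, at which 1 of the 4 values shown sits. From the compounds shown here alone, what remains open is whether an amine or a carboxylic acid on this aromatic carbon, or a longer chain in place of cyclopropyl, would stand apart from these values.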